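This account rests on a few compounds, and the source may have more. Where it says the series, first, only, none or still open, it means among the compounds named here.

Of the compounds shown here, three built on one shared core have been tested in a functional assay on HCT-116 cells (Homo sapiens) for inhibition, read by CCK-8 assay, with a stated time of 72 h, tested at 20 uM; a higher number here means more inhibition of growth at the concentration tested, a lower number less inhibition of growth. Compound 1 `CC(C)(C)OC(=O)/C=C1/C(=O)N(Cc2ccccc2)c2ccccc21` gives 87.9% in this assay. Compound 2 `Cc1ccc2c(c1)/C(=C\C(=O)OC(C)(C)C)C(=O)N2` gives 89.4% in this assay. Compound 3 `COc1ccc2c(c1)NC(=O)/C2=C/C(=O)OC(C)(C)C` gives 89.5% in this assay. Compound 2 sits with the second highest of the three numbers, yet both its neighbours lie within the usual scatter of the method, so the three readings cannot be told apart with confidence.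

Compound 4 `CC(C)(C)OC(=O)/C=C1/C(=O)Nc2ccc(Cl)cc21` differs from compound 2 in a single spot: chloro in place of methyl on an aromatic carbon. Among the compounds with values here, no directly measured pair in this set shows what this swap does, so the expectation rests only on how tightly the three measured compounds cluster near the top of the scale. The step of a number 1.4 percentage points lower from compound 2 to compound 4 (within the scatter) from compound 2 to compound 4 is therefore expected to stay within the scatter, with no clear direction. For compound 4 the estimate in this assay is 88%, with a range from 76% to 95%.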

Compound 4, percent growth inhibition at one concentration: 89.7%
Beside the measured number, compound 4's estimate is 1.7 percentage points below it, within the range that was stated.
By their numbers in this assay, from the lowest: compounds 1, 2, 3 and 4 (each within the scatter of the next).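

Placing chloro in place of methyl on this aromatic carbon, meta to a fused ring and para to a fused ring, gives a number 0.3 percentage points higher from compound 2 to compound 4 (within the scatter) in this assay. Within the data shown here, this is the first directly measured pair at this position, and it shows that exchanging one of these groups for the other, each with 1 heavy atom, leaves no difference that can be told from the scatter at this single test concentration. Nothing available here explains why the two groups read alike.

From the compounds shown here alone, it remains open whether a different group on this carbon, such as an amine, a carboxylic acid or a longer chain, would keep the reading this high. Going by these compounds, it also remains open whether chloro and methyl would separate at a lower concentration.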